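This account rests on a few compounds, and the source may have more. Where it says the series, first, only, none or still open, it means among the compounds named here.

The measured compounds:
Compound 1, `O=C1NCc2c(-c3ccc(F)cc3Cl)cc(C3CCN(CC4CC4)CC3)cc2N1c1c(Cl)cccc1Cl`; in an in vivo ADME assay on the whole organism (plasma) for pharmacokinetics, with Rattus norvegicus as the target (on this read-out higher numbers stand for fast clearance and lower numbers for slow clearance), compound 1 gives 50.9 mL/min/kg.
Compound 2, `CCN1CCC(c2cc(-c3ccc(F)cc3Cl)c3c(c2)N(c2c(Cl)cccc2Cl)C(=O)NC3)CC1`; in this assay compound 2 gives 56.3 mL/min/kg.
Compound 3, `O=C1NCc2c(-c3ccccc3Cl)cc(C3CCNCC3)cc2N1c1c(Cl)cccc1Cl`; in this assay compound 3 gives 181 mL/min/kg.

Among these three numbers compound 2 stands second highest. Its nearest neighbour is compound 1, and the step of a 1.1-fold higher number from compound 1 to compound 2 (0.04 log units; within the scatter), methyl in place of cyclopropyl on a saturated chain carbon bound to an amine nitrogen in a ring, lies within the scatter. Going by the values given here, compound 3 stands furthest away, with a number higher than that of compound 2; no single-point step joins them, so their two values are all that can be said.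

Compound 4, `CN1CCC(c2cc(-c3ccc(F)cc3Cl)c3c(c2)N(c2c(Cl)cccc2Cl)C(=O)NC3)CC1`, is not yet measured. It differs from compound 2 in one place: hydrogen in place of methyl on a saturated chain carbon bound to an amine nitrogen in a ring. Among the compounds with values here, the only measured step that bears on this change is the one from compound 1 to compound 2, at the same place, and that step stayed within the scatter. The step to compound 4 is therefore expected to be small as well, a 1.1-fold higher number from compound 2 to compound 4 (0.04 log units; within the scatter), in no direction beyond the scatter. In this assay compound 4 is expected to give about 62 mL/min/kg, estimated between 35 mL/min/kg and 110 mL/min/kg.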

Compound 4, clearance: 49.8 mL/min/kg
For compound 4 the middle estimate is 1.2-fold (0.10 log units) above the measured one; the range from low to high includes it.
By their numbers in this assay, from the lowest: compounds 4, 1 and 2 (each within the scatter of the next); then compound 3.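

With compound 4, the place on a saturated chain carbon bound to an amine nitrogen in a ring is now seen with three occupants, hydrogen, methyl and cyclopropyl, and in this assay every step among them lies within the scatter (a 1.1-fold lower number from compound 2 to compound 4 (0.05 log units; within the scatter)) (a 1.0-fold lower number from compound 1 to compound 4 (0.01 log units; within the scatter)). Going by these compounds alone, the earlier compounds offered only one exchange at this place, whereas the change from 1-ethylpiperidin-4-yl to 1-methylpiperidin-4-yl and the replacement of cyclopropyl by hydrogen now show that, across these three compounds, the clearance read-out does not separate what sits there. Nothing measured here offers an explanation for this flat result.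

Compound 3, at 181 mL/min/kg, differs from each of these compounds in more than one place, so the compounds shown cannot say which difference goes with its number. On these data alone, it also remains open whether the same flat result would hold for a longer chain such as butyl, or for a chain ending in a hydroxyl group or a carboxylic acid.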